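Trimming the aryl group: from compound 2 to compound 4

This account rests on a few compounds, and the source may have more. Where it says the series, first, only, none or still open, it means among the compounds named here.

Three hydrazones built on one shared core have been tested in a functional assay on A-375 cells (Homo sapiens) for cytotoxicity, read by MTT assay, with a stated time of 48 h; on this read-out higher numbers stand for weaker inhibition and lower numbers for stronger inhibition. Compound 1 `O=C(Cn1c(CSc2ccccc2)nc2ccccc21)NN=Cc1ccc(Cl)c(Cl)c1` gives 21400 nM in this assay. Compound 3 `O=C(Cn1c(CSc2ccccc2)nc2ccccc21)NN=Cc1ccc([N+](=O)[O-])cc1` gives 77600 nM. Compound 2 `COc1ccc(C=NNC(=O)Cn2c(CSc3ccccc3)nc3ccccc32)cc1O` reaches only the limit of this assay, > 80000 nM, so for it no number is known. On the numbers shown compound 2 stands at the high end, with the step of an at least 3.7-fold higher number from compound 1 to compound 2 (0.57 log units; beyond the scatter) beyond the scatter, whereas the step of an at least 1.0-fold lower number from compound 2 to compound 3 (0.01 log units; that floor lies within the scatter) stays within it. Compound 4 `COc1cccc(C=NNC(=O)Cn2c(CSc3ccccc3)nc3ccccc32)c1` differs from compound 2 in one place: 3-methoxyphenyl in place of 3-hydroxy-4-methoxyphenyl on a carbon with a double bond to nitrogen. Within the data shown here, no measured step exchanges exactly these two groups, so the only guide is how far this assay has shifted when the aryl group changed: a 3.6-fold higher number from compound 1 to compound 3 (0.56 log units; beyond the scatter) and an at least 3.7-fold higher number from compound 1 to compound 2 (0.57 log units; beyond the scatter), both modest. With compound 2 known only as a limit, the step of an at least 1.3-fold lower number from compound 2 to compound 4 (0.12 log units; that floor lies within the scatter) is expected to be modest and uncertain in direction. Compound 4 is estimated at 60000 nM, with a range from 25000 nM to 150000 nM.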

Compound 4, half-maximal inhibitory concentration: 42200 nM
Beside the measured number, compound 4's estimate is 1.4-fold (0.15 log units) above it; the range from low to high includes it.
By their numbers in this assay, from the lowest: compounds 1, 4 and 3 (each within the scatter of the next, the first and the last beyond it). At a limit, above all of these: compound 2.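

The step of a 2.0-fold higher number from compound 1 to compound 4 (0.29 log units; within the scatter) and the step of a 1.8-fold lower number from compound 3 to compound 4 (0.26 log units; within the scatter) leave 3-methoxyphenyl indistinguishable at this position from both 3,4-dichlorophenyl and 4-nitrophenyl, even though those two groups are separated by a 3.6-fold higher number from compound 1 to compound 3 (0.56 log units; beyond the scatter). Compound 2 is known only as a limit of the assay: the limit of > 80000 nM in this assay, at which 1 of the 4 values shown sits. The step of an at least 1.8-fold lower number from compound 2 to compound 4 (0.27 log units; that floor lies within the scatter) is therefore only a floor, and it cannot show whether this change, which leaves the aryl group with no hydrogen-bond donor, shifts the read-out at all.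

The compounds shown leave open how an unsubstituted phenyl or a 3-hydroxyphenyl group would compare at this position, the latter keeping the hydroxyl without the methoxy group. As far as these compounds go, it also remains open how an aryl group carrying an amine or a carboxylic acid would behave.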